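The compounds below may be only part of what the source reports. "The series", "measured", "known", "first", "only" and "open" are said of these compounds alone.

Results so far in a functional assay on A2780 cells (Homo sapiens) for antiproliferative activity; a lower number here means a stronger inhibitor, a higher number a weaker inhibitor

- compound 1 `CN(C)C(=O)N1Cc2ccccc2C(c2cccc(O)c2)C1` gives "not determined" (no result reported)
- compound 2 `CN(C)C(=O)N1Cc2cc(F)ccc2C(c2cccc(O)c2)C1` gives "not determined" (no result reported)
- compound 3 `CN(C)C(=O)N1Cc2cc(Br)ccc2C(c2cccc(O)c2)C1` gives 879 nM

For the measured compounds named here, only one compound in this small set has a usable number. Compound 1, the simplest of the three, has no result in this assay, and neither does compound 2. Going by the values given here, it therefore has no rank against the others, and no measured step starts from it. Compound 3 is the single reference point (879 nM).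

The next compound, compound 4 `Cc1cccc2c1CN(C(=O)N(C)C)CC2c1cccc(O)c1`, keeps the core of compound 1 and makes one small change (methyl in place of hydrogen on an aromatic carbon). A methyl replaces hydrogen on an aromatic carbon of a six-membered aromatic ring of carbon only, ortho to a fused ring.

Among the compounds with values here, no measured pair shows what such a swap does here, so any forecast is loose. The step from compound 1 cannot be sized, since its starting value is missing. Within the data shown here, the working expectation is a modest result of no dramatic strength, somewhat weaker than the only number available, which is that of compound 3 (879 nM).

For compound 4 the estimated value is 2000 nM, with an expected range from 500 nM to 8000 nM.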

Compound 4, half-maximal inhibitory concentration: 2050 nM
Compound 4: middle estimate off by 1.0-fold (0.01 log units), on the low side; the measured number falls inside the stated range.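

In this assay, for the compounds shown here, compound 1 has no single number and compound 4 gives 2050 nM, so no step between these two compounds can be read. The compounds shown leave open what methyl in place of hydrogen does to the activity of the shared core. Nothing available offers an explanation for the result of compound 4.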